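This account rests on a few compounds, and the source may have more. Where it says the series, first, only, none or still open, it means among the compounds named here.

Measured compounds:
- compound 1, `C#Cc1cn([C@@H]2O[C@H](CO)[C@@H](O)[C@H]2O)c2ncnc(OC)c12`: 380 nM
- compound 2, `C#Cc1cn([C@@H]2O[C@H](CO)[C@@H](O)[C@H]2O)c2ncnc(N(C)C)c12`: 260 nM

Both were tested in a functional assay on K562 cells (Homo sapiens), read by MTT assay, with a stated time of 72 h; on this read-out lower numbers stand for stronger inhibition and higher numbers for weaker inhibition. Compound 1 gives 380 nM, and compound 2 gives 260 nM; the two numbers sit within the scatter of each other, as the step of a 1.5-fold lower number from compound 1 to compound 2 (0.16 log units; within the scatter) shows. Compound 3, `CN(C)c1ncnc2c1c(-c1cccs1)cn2[C@@H]1O[C@H](CO)[C@@H](O)[C@H]1O`, differs from compound 2 by thiophen-2-yl in place of ethynyl on an aromatic carbon. Among the compounds with values here, the only measured step concerns a change at a different position, dimethylamino in place of methoxy on an aromatic carbon, and says nothing about swapping ethynyl for thiophen-2-yl. Within the data shown here, no measured step therefore bears on this change, and the expected size and direction of the step in this assay rests on the structural change alone, with wide uncertainty. Compound 3 is expected to give an estimate of 600 nM, within a range from 120 nM to 3000 nM. This estimate means an expected step of a 2.3-fold higher number from compound 2 to compound 3 (0.36 log units; beyond the scatter).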

Compound 3, half-maximal inhibitory concentration: > 20000 nM
Compound 3 ended at the assay's limit (the forecaster's own chance of this, stated with the estimate: 5%); at least 33-fold (1.52 log units) between middle value and limit.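

Within the data shown here, the earlier compounds varied only a different position, and that change stayed within the scatter, so compound 3 is the first to show how sensitive the carbon bearing ethynyl is. In this assay, replacing ethynyl with thiophen-2-yl gives an at least 76-fold higher number from compound 2 to compound 3 (1.88 log units; beyond the scatter), so this position does not accept every group, and a single change here can remove nearly all measurable activity. The value of compound 3, > 20000 nM, is a limit of the assay and not a number: the limit of > 20000 nM in this assay, at which 1 of the 3 values shown sits.

With only ethynyl and thiophen-2-yl shown at this place, it remains open which feature of the five-membered aromatic ring accounts for the loss. A methyl group, a bromine atom or a propynyl chain here could show whether any group other than ethynyl keeps the activity.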